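The compounds below may be only part of what the source reports. "The series", "measured", "known", "first", "only" and "open" are said of these compounds alone.

Working notes on the series. Compound 2 `O=C(CCCCCCc1ccccc1)c1ncc(-c2ccc(O)cc2)o1` gives 140 nM in an assay (Rattus norvegicus) for inhibition of Fatty-acid amide hydrolase 1 (Homo sapiens) (a higher number here means a weaker inhibitor, a lower number a stronger inhibitor), the lowest of the two numbers in hand. Among the compounds with values here, the only other point is compound 1 `COc1ccccc1-c1cnc(C(=O)CCCCCCc2ccccc2)o1`, which gives 400 nM in this assay; the single measured step is a 2.9-fold lower number from compound 1 to compound 2 (0.46 log units; beyond the scatter), the aryl group on the shared core being the one place that changed.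

Compound 3 `O=C(CCCCCCc1ccccc1)c1ncc(-c2ncccc2C(=O)O)o1` carries the change (3-carboxypyridin-2-yl in place of 4-hydroxyphenyl on an aromatic carbon). Within the data shown here, this again alters the aryl group, so the step from compound 1 to compound 2 is the only guide, and it shows that exchanging that group moved the number only modestly. Among the measured compounds shown here, no measured step covers a carboxy-bearing pyridinyl, so the direction for compound 3 is open; a step of similar or somewhat larger size than that seen is expected, a 2.9-fold higher number from compound 2 to compound 3 (0.46 log units; beyond the scatter), more likely toward a higher number. Compound 3 is estimated at 400 nM in this assay, with a range from 80 nM to 2500 nM.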

Compound 3, inhibition constant: > 50 nM
Compound 3: no number, only a limit; the forecaster's own chance of this, stated with the estimate: 10%; the middle value lies beyond the limit too.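

In this assay, compound 3 gives > 50 nM, which is a limit and not a number. The steps to compound 3 from compound 1 and compound 2 therefore cannot be read. The compounds shown leave open how 3-carboxypyridin-2-yl compares with 4-hydroxyphenyl and 2-methoxyphenyl on the shared core.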